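This account rests on a few compounds, and the source may have more. Where it says the series, first, only, none or still open, it means among the compounds named here.

Of the compounds shown here, three built on one shared core have been tested in a toxicity assay on THP-1 cells (Homo sapiens) for inhibition; a higher number here means that more compound is tolerated, a lower number that less compound is tolerated. Compound 1 (`Cn1c(-c2ccccc2)cnc1NC(=O)c1ccc(F)cc1`) gives > 100000 nM, which is a limit of the assay and not a number. Compound 2 (`Cn1c(-c2ccccc2)cnc1NC(=O)c1ccc(Cl)cc1`) gives > 100000 nM, which is also a limit. Compound 3 (`Cn1c(-c2ccccc2)cnc1NC(=O)c1cccc(Br)c1`) gives > 50000 nM, again a limit, and this limit is all that is known of where it stands.

Compound 4 (`Cn1c(-c2ccccc2)cnc1NC(=O)C1CCCCC1`) has cyclohexyl in place of 3-bromophenyl on a carbonyl carbon. Among the compounds with values here, none of the measured compounds has a non-aromatic ring at that place.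

Two measured steps also change the group on this carbonyl carbon: a step that the two limits leave unreadable from compound 1 to compound 3 and a step that the two limits leave unreadable from compound 2 to compound 3. Neither offers a size to carry over, and the same holds for a step that the two limits leave unreadable from compound 1 to compound 2. The expectation therefore rests on limits alone, and no step beyond the scatter is expected in this assay. It leans on compound 3, with its limit of > 50000 nM, and on compound 1, with its limit of > 100000 nM. The expected step is a step that the limit leaves unreadable from compound 3 to compound 4. The estimate for compound 4 is 80000 nM, with an expected range from 30000 nM to 100000 nM.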

Compound 4, half-maximal cytotoxic concentration: > 100000 nM
Compound 4 gave a limit, no number; the forecaster's own chance of this, stated with the estimate: 75%; middle value at least 1.2-fold (0.09 log units) away from the limit.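

In this assay compound 4 gives > 100000 nM, which is a limit of the assay and not a number. Compound 1, compound 2 and compound 3 also gave only limits, so the steps from each of them to compound 4 cannot be read. The compounds shown leave open at what concentration any of the four becomes toxic to these cells, and whether the group on the carbonyl carbon alters it.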